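The compounds below may be only part of what the source reports. "The series", "measured", "known", "first", "only" and "open" are said of these compounds alone.

Of the compounds shown here, three built on one shared core have been measured in an assay on MDA-MB-231 cells for displacement of a labelled ligand from C-X-C chemokine receptor type 4 (Homo sapiens), read by fluorescence and microscopy, with stated times of 10 min and 30 min; a higher number here means that more compound is needed for the effect, a lower number that less compound is needed. Compound 1, `O=C(NCc1ccc(CNS(=O)(=O)c2cccc(F)c2)cc1)c1cccnc1`, gives 1000 nM. Compound 2, `COc1ccccc1C(=O)NCc1ccc(CNS(=O)(=O)c2ccc(Cl)cc2)cc1`, gives 1000 nM, and compound 3, `Cc1ccccc1C(=O)NCc1ccc(CNS(=O)(=O)c2ccccc2Cl)cc1`, gives 1000 nM. On these numbers compound 1 stands level with compound 2 and with compound 3 at the digits reported; the gaps between the three lie within the usual scatter of repeated measurements, so none of them can be called stronger or weaker than another.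

The next compound to be measured is compound 4, `Cc1ccccc1S(=O)(=O)NCc1ccc(CNC(=O)c2cccnc2)cc1`. It differs from compound 1 in one place: 2-methylphenyl in place of 3-fluorophenyl on a sulfonyl sulfur. The change is 2-methylphenyl in place of 3-fluorophenyl on a sulfonyl sulfur, and the rest of the molecule is unchanged.

Going by the values given here, no pair of the measured compounds differs in only one place, so there is no comparable step to read from. What the three measured compounds show is that varying the groups at the ends of the shared core has left the readings level. On that basis the step from compound 1 to compound 4 in this assay is expected to be none beyond the scatter, no change at the digits printed from compound 1 to compound 4 (within the scatter). Compound 4 is therefore estimated at 1000 nM, within a range from 500 nM to 2000 nM.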

Compound 4, effective concentration (reported as EC, without a stated level of effect): 1000 nM
Compound 4: the middle estimate sits on the measured number at the digits printed, and the stated range covers the measured number.
By their numbers in this assay, from the lowest: compounds 1, 2, 3 and 4 (each within the scatter of the next).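

The step from 3-fluorophenyl to 2-methylphenyl on a sulfonyl sulfur gives, in this assay, no change at the digits printed from compound 1 to compound 4 (within the scatter). Going by these compounds alone, this is the first pair that differs in one place only, so the level readings can now be tied to a single change instead of to several differences at once. At this one position, with the rest of the molecule held fixed, one aromatic ring of carbon only can stand in for another with the same count of heavy atoms and no movement in the reading, although no measurement here offers an explanation for that.

Going by these compounds, only these two phenyl groups can be compared at this position, so it remains open whether a group of a different kind on the sulfonyl sulfur, such as a longer alkyl chain or a phenyl ring carrying an amine or a carboxylic acid, would shift the reading. Every compound shown gives the same reading, so it is also unknown which change to the shared core, at this position or elsewhere, would move the number at all.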